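The source may hold more compounds than are shown below. What is called first, only, known or untested is meant among the compounds shown, and "the series" means these compounds.

Of the compounds shown here, two with a shared core have been tested so far. In a functional assay on A549 cells (Homo sapiens) for antiproliferative activity, read by sulforhodamine B assay, with a stated time of 48 h (a higher number here means a weaker inhibitor, a lower number a stronger inhibitor), compound 1 (`O=C1CSC(c2cccc(Br)c2)N1c1ncccn1`) gives > 50000 nM, which is a limit of the assay and not a number. Compound 2 (`C=CCN(CC=C)C(=O)c1cccc(C2SCC(=O)N2c2ccccc2OC)c1`) gives > 50000 nM, which is also a limit. Neither compound therefore offers an actual number for comparison, and the evidence so far is the limit of > 50000 nM in this assay, at which 2 of the 2 values shown sit.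

The next compound, compound 3 (`COc1ccccc1N1C(=O)CSC1c1cccc(C(=O)Nc2ccccc2)c1`), keeps the core of compound 2 and changes one group, with anilino in place of diallylamino on a carbonyl carbon. Among the measured compounds shown here, no measured step shows what such a swap does. The starting point is only compound 2 at > 50000 nM, a limit, so only a small move toward stronger inhibition is expected. The expected change is an at least 1.2-fold lower number from compound 2 to compound 3 (0.09 log units; that floor lies within the scatter). For compound 3 the estimated value is 40000 nM, with an expected range from 12000 nM to 100000 nM.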

Compound 3, half-maximal inhibitory concentration: > 25000 nM
Compound 3 was reported as a limit (the forecaster's own chance of this, stated with the estimate: 60%); the middle value is on the limit's open side.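

Compound 2 and compound 3 are both reported only as limits in this assay, so no step can be read between them. The compounds shown leave open whether anilino in place of diallylamino on a carbonyl carbon changes the result at all.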